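A few compounds are considered here, and "the series" means these few. Any claim that something is new, unique, unknown or untested is made for them only; others in the source may bear on it.

Measured so far in a functional assay on NCI-H460 cells (Homo sapiens) for cytotoxicity, read by MTT assay, with a stated time of 72 h; a higher number here means a weaker inhibitor, a lower number a stronger inhibitor:
- compound 1 `CC(C)(C)C1=CC(=O)C=CC1=O` gives 72000 nM
- compound 2 `CCNC1=CC(=O)C(C(C)(C)C)=CC1=O` gives 65000 nM

Within the data shown here, with only two measured compounds, compound 2 stands level with compound 1. Among the measured compounds shown here, the one measured step, a 1.1-fold lower number from compound 1 to compound 2 (0.04 log units; within the scatter), places ethylamino in place of hydrogen on a double-bonded ring carbon.

Next is compound 3 `CC(C)(C)C1=CC(=O)C(NCc2ccccc2)=CC1=O`, with phenyl in place of methyl on a saturated chain carbon bound to an amine nitrogen. This is phenyl in place of methyl on a saturated chain carbon bound to an amine nitrogen. For the measured compounds named here, no measured step covers a change at that carbon, so the earlier step bears on it only loosely. With no other evidence, the expectation in this assay starts from compound 2 at 65000 nM, and no shift beyond the scatter is foreseen. The step expected is a 1.4-fold lower number from compound 2 to compound 3 (0.16 log units; within the scatter). For compound 3 the estimated value is 45000 nM, with an expected range from 15000 nM to 100000 nM.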

Compound 3, half-maximal inhibitory concentration: 15000 nM
For compound 3 the middle estimate is 3.0-fold (0.48 log units) above the measured one; the range from low to high includes it.
By their numbers in this assay, from the lowest: compound 3; then compounds 2 and 1 (each within the scatter of the next).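

In this assay, among these compounds, the saturated chain carbon bound to the amine nitrogen is the first place where a single change moves the number beyond the scatter: phenyl in place of methyl gives a modest gain (a 4.3-fold lower number from compound 2 to compound 3 (0.64 log units; beyond the scatter)). The earlier ethylamino step on the double-bonded ring carbon stayed within the scatter (a 1.1-fold lower number from compound 1 to compound 2 (0.04 log units; within the scatter)), so the amine-bearing compounds differ from one another through what sits on this chain carbon, at least for this one pair. Nothing measured here accounts for the gain.

The compounds shown hold only methyl and phenyl at this carbon, so it remains open whether an aromatic ring is needed or whether a cyclohexyl group or a longer chain such as butyl would serve as well. From the compounds shown here alone, how a methoxy group or a chlorine on the phenyl ring would shift the number also remains open.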